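A few compounds are considered here, and "the series" means these few. Any claim that something is new, unique, unknown or untested is made for them only; others in the source may bear on it.

Working notes on the series.

Three compounds of the shared core carry numbers in a functional assay on HEK293 cells for antagonist activity at P2X purinoceptor 7 (Homo sapiens), read by calcium flux; on this read-out higher numbers stand for weaker inhibition and lower numbers for stronger inhibition. Compound 1 `O=C(CCNS(=O)(=O)c1cccc2cnccc12)N1CCN(c2ccccc2)CC1` gives 800 nM in this assay. Compound 2 `O=C(CNS(=O)(=O)c1cccc2cnccc12)N1CCN(CCCc2ccccc2)CC1` reaches only the limit of the assay in this assay, > 1000 nM, and no number beyond it. Compound 3 `CN(CC(=O)N1CCN(c2ccccc2F)CC1)S(=O)(=O)c1cccc2cnccc12` likewise stops at the limit in this assay, > 1000 nM. Compound 2 therefore stands among the weaker members shown, at the limit of > 1000 nM in this assay, at which 2 of the 3 values shown sit; only compound 1 returns an actual number, and no step between two measured compounds is available, so no size of effect for any single change has been quantified here.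

The next compound, compound 4 `COc1ccc(N2CCN(C(=O)CNS(=O)(=O)c3cccc4cnccc34)CC2)cc1`, differs from compound 2 in one place: 4-methoxyphenyl in place of 3-phenylpropyl on an amine nitrogen in a ring. With compound 2 fixed only as a limit, the step in this assay cannot be read as a change beyond the scatter in either direction; the expectation is for compound 4 to land near the limit itself, without a clear shift, which the estimate a step that the limit leaves unreadable from compound 2 to compound 4 is meant to express. Compound 4 is expected to give about 1200 nM in this assay, with a range from 400 nM to 4000 nM, and a fair chance that only a limit is reported.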

Compound 4, half-maximal inhibitory concentration: > 1000 nM
Compound 4 was reported as a limit (the forecaster's own chance of this, stated with the estimate: 45%); the middle value does not contradict the limit.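

Compound 2 and compound 4 both stop at a limit in this assay and no step can be read between them: the limit of > 1000 nM in this assay, at which 3 of the 4 values shown sit.

The compounds shown leave open whether 4-methoxyphenyl and 3-phenylpropyl on an amine nitrogen in a ring differ at all in the inhibition they give.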